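Extending the Carbamate Ester: Ethyl to Benzyl

A few compounds are considered here, and "the series" means these few. Any claim that something is new, unique, unknown or untested is made for them only; others in the source may bear on it.

Compound 1, `CCCCOC(=O)Nc1ccc([Se]C#N)cc1`: 5000 nM
Compound 2, `CCOC(=O)Nc1ccc([Se]C#N)cc1`: 21700 nM

Both compounds were tested in an ADME assay on BEAS-2B cells (Homo sapiens) for cytotoxicity, read by MTT assay, with a stated time of 72 h; a lower number here means a stronger inhibitor of growth, a higher number a weaker inhibitor of growth. Among the compounds with values here, of the two numbers, compound 2 stands highest with 21700 nM; its only neighbour is compound 1, and the step between them is a 4.3-fold higher number from compound 1 to compound 2 (0.64 log units; beyond the scatter), namely hydrogen in place of ethyl on a saturated chain carbon, two bonds along the chain from an oxygen next to a carbonyl group. Compound 3, `N#C[Se]c1ccc(NC(=O)OCc2ccccc2)cc1`, has not yet been measured. It differs from compound 2 by phenyl in place of methyl on a saturated chain carbon bound to an oxygen next to a carbonyl group. Within the data shown here, the one measured step that bears on this change is a 4.3-fold higher number from compound 1 to compound 2 (0.64 log units; beyond the scatter), where a shorter chain went with a higher number. Making the group on that carbon larger again is therefore expected to lower the number in this assay, by an estimated step of a 4.3-fold lower number from compound 2 to compound 3 (0.64 log units; beyond the scatter). Compound 3 is accordingly estimated at 5000 nM, with an expected range from 1500 nM to 16000 nM.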

Compound 3, concentration for 50% growth inhibition: 100 nM
Estimate against measurement, compound 3: 50-fold (1.70 log units) above; the whole stated range lies above it.
By their numbers in this assay, from the lowest: compound 3; then compound 1; then compound 2.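

In this assay, within the data shown here, the earlier pair showed only that chain length matters on this ester side; phenyl in place of methyl on a saturated chain carbon bound to an oxygen next to a carbonyl group brings a far larger change, a 220-fold lower number from compound 2 to compound 3 (2.34 log units; beyond the scatter), which means much stronger inhibition of growth. The longer chain of compound 1 does not account for this gain, since phenyl in place of propyl still gives a 50-fold lower number from compound 1 to compound 3 (1.70 log units; beyond the scatter), so among these three compounds, the aromatic ring goes with a much lower number than either saturated chain. No measured evidence here explains why the ring has this effect.

The compounds shown leave open whether a longer chain ending in phenyl would keep so low a number. They also leave open how a pyridine ring, or a phenyl ring carrying a chlorine atom, would compare at this position.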